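Three limits and a nitro question

The source may hold more compounds than are shown below. What is called first, only, known or untested is meant among the compounds shown, and "the series" means these compounds.

Values from an ADME assay on MT4 cells (Homo sapiens) for cytotoxicity, read by MTT assay (on this read-out higher numbers stand for lower toxicity in this test and lower numbers for higher toxicity in this test), follow, each one a limit
Compound 1 `O=c1cc(Cc2c(F)cccc2F)nc(SCc2ccccc2)[nH]1` gives > 73000 nM as a limit
Compound 2 `O=c1cc(Cc2c(F)cccc2F)nc(SCc2c(F)cccc2F)[nH]1` gives > 66000 nM as a limit
Compound 3 `O=C(CSc1nc(Cc2c(F)cccc2F)cc(=O)[nH]1)c1ccccc1` gives > 67000 nM as a limit

No number places compound 3, which has only a limit, as do the other two. Compound 4 `O=C(CSc1nc(Cc2c(F)cccc2F)cc(=O)[nH]1)c1ccc([N+](=O)[O-])cc1` makes one change to it: nitro in place of hydrogen on an aromatic carbon. The measured steps are a step that the two limits leave unreadable from compound 1 to compound 2, a step that the two limits leave unreadable from compound 1 to compound 3 and a step that the two limits leave unreadable from compound 2 to compound 3. All three alter the group on the chain carbon, none involves nitro, and no size can be read from them. In this assay no step beyond the scatter is therefore expected, with compound 3 resting at > 67000 nM as a limit. The expected step is an at least 1.1-fold lower number from compound 3 to compound 4 (0.04 log units; that floor lies within the scatter). For compound 4 the estimated value is 60000 nM, within an expected range from 20000 nM to 90000 nM.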

Compound 4, half-maximal cytotoxic concentration: 22000 nM
The estimate for compound 4 lay 2.7-fold (0.44 log units) above the measured number, and the stated range covers the measured number.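

In this assay, nitro in place of hydrogen on an aromatic carbon, para to a large group, gives an at least 3.0-fold lower number from compound 3 to compound 4 (0.48 log units; beyond the scatter), so a change at this place can move the read-out towards higher toxicity in this test. Going by these compounds alone, the steps among compound 1, compound 2 and compound 3 cannot be read, which makes this the first readable step here. Its full size stays unknown, because compound 3 has only a limit: the limit of > 67000 nM in this assay, at which 1 of the 4 values shown sits.

Going by these compounds, whether this step belongs to nitro alone remains open. An amine or a carboxylic acid on the same aromatic carbon would show whether other groups there give a similar step.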